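The source may report more compounds than this note shows. Statements on the series, on what has been measured and on what is new or still open speak of the compounds shown alone.

Compound 1 `O=C(CCc1ccc(C(F)(F)F)cc1)Nc1ccc2nc(N3CCC3)ccc2c1`: in a functional assay on HEK293 cells for activation of melanin-concentrating hormone receptor 1 (Rattus norvegicus), read by inositol phosphate accumulation (a higher number here means that more compound is needed for the effect, a lower number that less compound is needed), compound 1 gives 56 nM.
Compound 2 `O=C(CCc1ccc(C(F)(F)F)cc1)Nc1ccc2nc(N3CCC(NS(=O)(=O)O)C3)ccc2c1`: in this assay compound 2 gives 50 nM.

Compound 2 holds the lower of the two numbers, yet the step of a 1.1-fold lower number from compound 1 to compound 2 (0.05 log units; within the scatter) lies within the scatter, so neither compound is set apart. Compound 3 `CC(C)N(C)c1ccc2cc(NC(=O)CCc3ccc(C(F)(F)F)cc3)ccc2n1` differs from compound 2 by isopropyl(methyl)amino in place of 3-(sulfoamino)pyrrolidin-1-yl on an aromatic carbon. Among the measured compounds shown here, the only step bearing on this site, a 1.1-fold lower number from compound 1 to compound 2 (0.05 log units; within the scatter), exchanged one cyclic amine for another and moved nothing beyond the scatter. For the measured compounds named here, no measured step covers an amine with no ring, so a change beyond the scatter is not expected. Compound 3 is therefore estimated at 50 nM, range 20 nM to 130 nM, a step of no change at the digits printed from compound 2 to compound 3 (within the scatter).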

Compound 3, half-maximal effective concentration: 140 nM
Estimate against measurement, compound 3: 2.8-fold (0.45 log units) below; measured number above the stated range.
By their numbers in this assay, from the lowest: compounds 2 and 1 (each within the scatter of the next); then compound 3.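

Among the compounds shown here, at this position, next to the ring nitrogen, isopropyl(methyl)amino is the first change to move the number beyond the scatter: a 2.8-fold higher number from compound 2 to compound 3 (0.45 log units; beyond the scatter) and a 2.5-fold higher number from compound 1 to compound 3 (0.40 log units; beyond the scatter), both modest. Azetidin-1-yl and 3-(sulfoamino)pyrrolidin-1-yl remain within the scatter of each other, so among these three compounds only the amine with no ring stands apart. Nothing available here explains the shift.

Going by these compounds, whether the step follows from the missing ring or from the particular isopropyl and methyl groups stays open. Dimethylamino and piperidin-1-yl on this carbon would help separate those two readings.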